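This account rests on a few compounds, and the source may have more. Where it says the series, first, only, none or still open, it means among the compounds named here.

Values so far in a functional assay on HeLa cells (Homo sapiens) for inhibition, read by MTT assay, with a stated time of 48 h; on this read-out higher numbers stand for weaker inhibition and lower numbers for stronger inhibition
Compound 1 `COc1ccc(C(c2c[nH]c3ccc(Br)cc23)c2c[nH]c3ccc(Br)cc23)c(OC)c1` gives 63200 nM
Compound 2 `COc1ccc(C(c2c[nH]c3ccc(Br)cc23)c2c[nH]c3ccc(Br)cc23)cc1OC` gives 6100 nM
Compound 3 `CCCC(c1c[nH]c2ccc(Br)cc12)c1c[nH]c2ccc(Br)cc12` gives 3900 nM

Compound 3 sits level with compound 2 at the low end of these numbers (a 1.6-fold lower number from compound 2 to compound 3 (0.19 log units; within the scatter)) and well clear of compound 1 (a 16-fold lower number from compound 1 to compound 3 (1.21 log units; beyond the scatter)). Compound 4 `CCCCCCCC(c1c[nH]c2ccc(Br)cc12)c1c[nH]c2ccc(Br)cc12` differs from compound 3 by a single change (butyl in place of hydrogen on a saturated chain carbon, four bonds along the chain from two aromatic carbons), which can equally be read as propyl to heptyl. The measured steps at this part of the molecule all exchange a dimethoxyphenyl group. The large ones both start from compound 1 (a 10-fold lower number from compound 1 to compound 2 (1.02 log units; beyond the scatter)), and none lengthens a chain. No step beyond the scatter is therefore expected in this assay. The estimated change is a 1.1-fold lower number from compound 3 to compound 4 (0.05 log units; within the scatter) and carries wide uncertainty. For compound 4 the expected value is 3500 nM with a range of 1300 nM to 12000 nM as estimated here.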

Compound 4, half-maximal inhibitory concentration: 1300 nM
Estimate against measurement, compound 4: 2.7-fold (0.43 log units) above; the measured number falls inside the stated range.
By their numbers in this assay, from the lowest: compound 4; then compounds 3 and 2 (each within the scatter of the next); then compound 1.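

Lengthening the chain at this carbon, read as propyl to heptyl, brings the first measured gain from a chain change, and it lies beyond the scatter (a 3.0-fold lower number from compound 3 to compound 4 (0.48 log units; beyond the scatter)). Heptyl also surpasses both aryl groups at this carbon (a 4.7-fold lower number from compound 2 to compound 4 (0.67 log units; beyond the scatter); a 49-fold lower number from compound 1 to compound 4 (1.69 log units; beyond the scatter)), making compound 4 the strongest inhibitor of the four, where propyl in compound 3 could not be separated from the 3,4-dimethoxyphenyl group in compound 2.

With only two chain lengths shown, it remains open whether a longer chain such as decyl, or a heptyl chain ending in an amine or a carboxylic acid, would lower the number further. Nothing available explains the gain from the longer chain.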